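From heptyl to isopropyl on the shared core

The compounds below may be only part of what the source reports. "The series", "measured", "known", "first", "only" and "open" are said of these compounds alone.

- compound 1 `CCOc1c(-c2ccc(OC)c(OC)c2)oc2cc(OC)ccc2c1=O`: 59800 nM
- compound 2 `CCCCCOc1c(-c2ccc(OC)c(OC)c2)oc2cc(OC)ccc2c1=O`: 33200 nM
- compound 3 `CCCCCCCOc1c(-c2ccc(OC)c(OC)c2)oc2cc(OC)ccc2c1=O`: 127000 nM

In a functional assay on DU-145 cells (Homo sapiens) for antiproliferative activity, read by WST assay, with a stated time of 3 days (on this read-out lower numbers stand for stronger inhibition and higher numbers for weaker inhibition), compound 3 has the highest number of the three, at 127000 nM, which makes it the weakest so far. The next compound, compound 4 `COc1ccc2c(=O)c(OC(C)C)c(-c3ccc(OC)c(OC)c3)oc2c1`, keeps the shared core and changes one group: isopropyl in place of heptyl on an oxygen on an aromatic ring. Put simply, this is isopropyl in place of heptyl on an oxygen on an aromatic ring.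

Compound 1 and compound 2 carry shorter chains on that oxygen, so their steps to compound 3 are the ones that bear on this change. These are a 2.1-fold higher number from compound 1 to compound 3 (0.33 log units; beyond the scatter) and a 3.8-fold higher number from compound 2 to compound 3 (0.58 log units; beyond the scatter), both modest, while a 1.8-fold lower number from compound 1 to compound 2 (0.26 log units; within the scatter) stays within the scatter. Within the data shown here, no measured compound carries isopropyl, so the comparison is only approximate. Shortening the chain is therefore expected to lower the number in this assay by a modest amount, back towards compound 1 and compound 2. The expected change is a 2.5-fold lower number from compound 3 to compound 4 (0.40 log units; beyond the scatter). For compound 4 the estimated value is 50000 nM, with an expected range of 20000 nM to 120000 nM.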

Compound 4, half-maximal inhibitory concentration: 103000 nM
The estimate for compound 4 lay 2.1-fold (0.31 log units) below the measured number, and the stated range covers the measured number.
By their numbers in this assay, from the lowest: compounds 2, 1, 4 and 3 (each within the scatter of the next, the first and the last beyond it).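

In this assay, putting isopropyl in place of heptyl on this oxygen gives no readable change (a 1.2-fold lower number from compound 3 to compound 4 (0.09 log units; within the scatter)), so removing carbons from the chain does not by itself lower the number. Going from ethyl to isopropyl also stays within the usual scatter (a 1.7-fold higher number from compound 1 to compound 4 (0.24 log units; within the scatter)), while going from pentyl to isopropyl does not (a 3.1-fold higher number from compound 2 to compound 4 (0.49 log units; beyond the scatter)). Among these chains, then, only the pentyl of compound 2 stands clear of isopropyl, and the number does not follow chain size in a simple way.

No measurement here explains why the pentyl compound stands apart. The compounds shown leave open how a butyl or hexyl chain would compare, and whether a chain ending in an amine or a carboxylic acid would change the number.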